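The compounds below may be only part of what the source reports. "The series", "measured", "known", "first", "only" and "open" are said of these compounds alone.

Measured so far:
compound 1, `Cc1cc(F)cc(Nc2cc(NC(=O)Nc3c(Cl)cccc3Cl)ncn2)c1`, 80%
compound 2, `COc1cc(NC(=O)Nc2cc(Nc3ccc(F)c(Cl)c3)ncn2)cc(OC)c1`, 77.5%
compound 3, `CCc1ccc(Nc2cc(NC(=O)Nc3c(Cl)cccc3Cl)ncn2)cc1`, 70.1%

In a functional assay on PC-9 cells (Homo sapiens) for inhibition, read by MTT assay, with a stated time of 48 h, tested at 10 uM (on this read-out lower numbers stand for less inhibition and higher numbers for more inhibition at the one concentration tested (going by the name of the read-out)), compound 2 gives 77.5%. Its number sits between those of compound 1 and compound 3, and both of those lie within the scatter of it, so the three measured compounds are not separated on this read-out.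

Compound 4, `COc1cc(NC(=O)Nc2cc(Nc3cc(C)cc(F)c3)ncn2)cc(OC)c1`, is not yet measured. It differs from compound 2 in one place: 3-fluoro-5-methylphenyl in place of 3-chloro-4-fluorophenyl on a nitrogen on an aromatic ring.

Going by the values given here, the one step among the measured compounds that touches the entering group is a number 9.9 percentage points lower from compound 1 to compound 3 (within the scatter), where the 3-fluoro-5-methylphenyl group of compound 1 is exchanged for 4-ethylphenyl on the same nitrogen with no movement beyond the scatter. Among the compounds with values here, no measured pair exchanges 3-chloro-4-fluorophenyl. Within the data shown here, compound 1, which carries the 3-fluoro-5-methylphenyl group of compound 4, and compound 2 show values within the scatter of each other, though they also differ at the other aryl group, so that pair gives no clean step.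

On this basis no step beyond the scatter is expected in this assay for compound 4; the estimated step is a number 0.5 percentage points higher from compound 2 to compound 4 (within the scatter). Compound 4 is therefore expected to give 78%, within the range 65% to 88%.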

Compound 4, a percentage reported as inhibition, at one concentration (the size of the read-out at that concentration, not a potency): 64.5%
The estimate for compound 4 lay 13.5 percentage points above the measured number; the whole stated range lies above it.
By their numbers in this assay, from the lowest: compounds 4, 3, 2 and 1 (each within the scatter of the next, the first and the last beyond it).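

In this assay, going by these compounds alone, the step at this nitrogen is a number 13 percentage points lower from compound 2 to compound 4 (beyond the scatter), the first step beyond the scatter, so the choice of aryl group here can move the read-out. The earlier exchange at the same position, a number 9.9 percentage points lower from compound 1 to compound 3 (within the scatter), gave no such separation, and it involved a different pair of groups on a different partner. The 3-fluoro-5-methylphenyl group does not fix the number by itself: compound 1 gives 80% and compound 4 gives 64.5% with this same group, while the two differ only at the other aryl group on the urea. No measurement at hand accounts for the step or identifies which part of the exchange drives it.

Still open is whether the step from 3-chloro-4-fluorophenyl to 3-fluoro-5-methylphenyl has the same size with the other aryl group of compound 1, since the compounds shown include no partner for that comparison. Also open is how this nitrogen-linked ring responds to a primary amine or a carboxylic acid, neither of which appears on it among these compounds, and a single-concentration read-out gives no potency for any of them.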